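Notes on the shared core: chloro to methoxy on the anilino ring

The compounds below may be only part of what the source reports. "The series", "measured", "known", "first", "only" and "open" are said of these compounds alone.

Measured so far in a functional assay on A549 cells (Homo sapiens) for cytotoxicity, read by MTT assay, with a stated time of 72 h; on this read-out lower numbers stand for stronger inhibition and higher numbers for weaker inhibition:
compound 1, `CCOC(=O)c1c(C)oc2ncnc(Nc3cccc(Cl)c3)c12`, gives > 1000000 nM.
compound 2, `Cc1oc2ncnc(Nc3cccc(Cl)c3)c2c1C(=O)NC(C)C`, gives > 1000000 nM.
compound 3, `CCOC(=O)c1c(C)oc2ncnc(Nc3ccc(OCc4cccc(F)c4)c(Cl)c3)c12`, gives 500 nM.

For compound 1 the value in this assay is a limit of the assay, not a number. The value of compound 2 is likewise a limit. Only compound 3 gives a number. Two of the three values shown sit at the limit of > 1000000 nM in this assay, at which 2 of the 3 values shown sit. The step that the two limits leave unreadable from compound 1 to compound 2 is left unreadable by the two limits. The step of an at least 2000-fold lower number from compound 1 to compound 3 (3.30 log units; beyond the scatter) is large and well beyond the scatter.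

Compound 4, `CCOC(=O)c1c(C)oc2ncnc(Nc3cccc(OC)c3)c12`, is not yet measured in this assay. It differs from compound 1 by methoxy in place of chloro on an aromatic carbon. Neither measured step touches this place: one changes the group on a carbonyl carbon, the other enters a group on a different aromatic carbon. Because compound 1 stands at > 1000000 nM, a limit, there is no footing for expecting a number from so small a change. The expected step of a number no higher from compound 1 to compound 4 (the limit leaves the size open) is none beyond the scatter. Compound 4 is estimated at 1000000 nM, within 100000 nM to 10000000 nM, most likely reported again only as a limit.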

Compound 4, half-maximal inhibitory concentration: > 1000000 nM
Compound 4 was reported as a limit; the forecaster's own chance of this, stated with the estimate: 70%; the middle value lies on the limit itself.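

Compound 1 and compound 4 both stand at a limit of the assay, not a number, so no new step can be read between them: the limit of > 1000000 nM in this assay, at which 3 of the 4 values shown sit.

The compounds shown leave open whether methoxy in place of chloro shifts the value at all in a compound that gives a number.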